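Replacing a methoxybenzyl amide with an amino acid group

This account rests on a few compounds, and the source may have more. Where it says the series, first, only, none or still open, it means among the compounds named here.

Compound 1, `CCN(CC)CCNC(=O)c1ccc(C(CC)(CC)c2ccc(OCC(O)C(C)(C)C)c(C)c2)n1CC`, gives 6.54 nM in an assay on cells for agonist activity at vitamin D3 receptor (Homo sapiens), read by microscopy; a lower number here means that less compound is needed, a higher number that more compound is needed for the effect.
Compound 2, `CCn1c(C(=O)NCc2ccc(OC)cc2)ccc1C(CC)(CC)c1ccc(C#CC(O)(CC)CC)c(C)c1`, reaches only the assay limit of > 50 nM in this assay, so no number is known for it.
Compound 3, `CCn1c(C(=O)NCC(=O)O)ccc1C(CC)(CC)c1ccc(C#CC(O)(CC)CC)c(C)c1`, gives 9.36 nM in this assay.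

Compound 2 therefore stands at the edge of what was measured: the limit of > 50 nM in this assay, at which 1 of the 3 values shown sits. The step from compound 2 to compound 4, `CCn1c(C(=O)N[C@H](C(=O)O)C(C)C)ccc1C(CC)(CC)c1ccc(C#CC(O)(CC)CC)c(C)c1`, is the change (1-carboxy-2-methylpropyl in place of 4-methoxybenzyl on an amide-type nitrogen). Going by the values given here, only one measured step bears on this: an at least 5.3-fold lower number from compound 2 to compound 3 (0.72 log units; beyond the scatter). Among the compounds with values here, that step swaps the same 4-methoxyphenyl for a carboxy on the chain carbon, and compound 4 carries that carboxy too, together with a methyl-branched chain in the 1-carboxy-2-methylpropyl group, which no measured pair tests. The expectation is a step downward of about the same size as seen for compound 3, an at least 5.0-fold lower number from compound 2 to compound 4 (0.69 log units; beyond the scatter), rather than no change. Compound 4 is estimated at 10 nM in this assay, with a likely range from 3 nM to 40 nM, since the untested branch could shift the number either way.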

Compound 4, half-maximal effective concentration: 17.7 nM
Compound 4: the middle estimate sits 1.8-fold (0.25 log units) below what was measured; the range from low to high includes it.
By their numbers in this assay, from the lowest: compounds 1, 3 and 4 (each within the scatter of the next, the first and the last beyond it). At a limit, above all of these: compound 2.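

In this assay, going by these compounds alone, the earlier compounds tied the carboxy group to a lower number only on the unbranched chain of compound 3. The new result extends this to the branched 1-carboxy-2-methylpropyl group, with an at least 2.8-fold lower number from compound 2 to compound 4 (0.45 log units; beyond the scatter). Placing an isopropyl on the saturated chain carbon bound to the amide-type nitrogen and the carbonyl carbon gives a 1.9-fold higher number from compound 3 to compound 4 (0.28 log units; within the scatter), so this position accepts the isopropyl without a difference that can be told from the scatter. The step from compound 2 gives only a minimum size, because compound 2 is known only as a limit: the limit of > 50 nM in this assay, at which 1 of the 4 values shown sits.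

The compounds shown leave open whether the carboxy group itself is needed, since nothing here tests a methyl ester, a primary amide or a tetrazole in its place on the same chain. They also leave open how far this position tolerates larger groups such as a benzyl or a longer chain, and whether the mirror-image form of the defined stereocentre in compound 4 would give a similar number.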